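A few compounds are considered here, and "the series" means these few. Any claim that something is new, unique, unknown or untested is made for them only; others in the source may bear on it.

Three related compounds have been measured in an ADME assay on microsomes from liver (Mus musculus) for metabolic stability, read by LC-MS, using NADPH, with a stated time of 60 min, tested at 1 uM; a higher number here means that the compound lasts longer, a lower number that the compound disappears faster. Compound 1 `O=C(O)CCc1cc2ccc(-c3cc(F)cc(OC(F)F)c3)cc2n1S(=O)(=O)c1cccc(C(F)(F)F)c1` gives > 2.41 h, which is a limit of the assay and not a number. Compound 2 `O=C(O)CCC1Cc2ccc(-c3cc(F)cc(OC(F)F)c3)cc2N1S(=O)(=O)c1cccc(C(F)(F)F)c1` gives 1.02 h, and compound 3 `O=C(O)CCCC1CN(S(=O)(=O)c2cccc(C(F)(F)F)c2)c2cc(-c3cc(F)cc(OC(F)F)c3)ccc21` gives 0.57 h. These last two values lie within the usual scatter of each other, so compound 2 and its nearest neighbour, compound 3, cannot be ranked against one another.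

Compound 4 `O=C(CC1Cc2ccc(-c3cc(F)cc(OC(F)F)c3)cc2N1S(=O)(=O)c1cccc(C(F)(F)F)c1)N1CC2(COC2)C1` has not yet been measured. It differs from compound 2 in one place: a group of 9 heavy atoms (6 carbon, 1 nitrogen, 2 oxygen; 2 four-membered non-aromatic rings with 1 hetero atom each) in place of a group of 4 heavy atoms (2 carbon, 2 oxygen; no ring), on a saturated chain carbon bound to a saturated ring carbon. Put simply, on a saturated chain carbon bound to a saturated ring carbon, a carboxymethyl group of 4 heavy atoms gives way to a larger group of 9 heavy atoms, with 2 four-membered non-aromatic rings with 1 hetero atom each.

For the measured compounds named here, no measured pair shows a change of this kind, so the expectation rests on little. Going by the values given here, it leans on compound 3, whose 0.57 h is the only other true number available. The expected step, a 1.7-fold lower number from compound 2 to compound 4 (0.23 log units; within the scatter), is a small fall that stays within the scatter. For compound 4 the estimated half-life is 0.6 h, with an expected range from 0.2 h to 1.6 h.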

Compound 4, half-life: 0.0117 h
Compound 4: middle estimate off by 51-fold (1.71 log units), on the high side; measured number below the stated range.
By their numbers in this assay, from the lowest: compound 4; then compounds 3 and 2 (each within the scatter of the next). At a limit, above all of these: compound 1.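

In this assay, the saturated chain carbon bound to a saturated ring carbon proves to be a highly sensitive place, since replacing the carboxymethyl group with the larger group carrying 2 four-membered non-aromatic rings with 1 hetero atom each gives an 87-fold lower number from compound 2 to compound 4 (1.94 log units; beyond the scatter). For the compounds shown here, no earlier pair differed in one place, so this is the first direct reading of any single change, and it lies well beyond the scatter. The swap takes the group from 1 hydrogen-bond donor to 0 hydrogen-bond donors and also enlarges it, and nothing measured here shows which of these differences, if either, accounts for the fall.

A simple dimethylamide or a methyl ester at the same place would help to show whether losing the carboxylic acid is enough for such a fall, or whether the two rings matter. The same change on the core of compound 1 also remains open, and that compound offers no exact starting number, as its value is a limit: the limit of > 2.41 h in this assay, at which 1 of the 4 values shown sits.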